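Fluoro to chloro in a cytotoxicity read-out

The source may report more compounds than this note shows. Statements on the series, on what has been measured and on what is new or still open speak of the compounds shown alone.

Compound 1 `Cc1cc(NC(=O)Nc2ccc(F)c(F)c2)c2ccccc2n1` gives > 25000 nM in an ADME assay on HEK293 cells (Homo sapiens) for cytotoxicity, with a stated time of 72 h; on this read-out higher numbers stand for an effect only at larger amounts of compound and lower numbers for an effect already at smaller amounts; this is a limit of the assay.
Compound 2 `Cc1cc(NC(=O)Nc2ccc(F)cc2)c2ccccc2n1` gives > 25000 nM in this assay; this is a limit of the assay.
Compound 3 `COC(=O)c1cccc(NC(=O)Nc2cc(C)nc3ccccc23)c1` gives 26000 nM in this assay.

Compound 2 thus stands at the upper edge of what this assay can report, and none of the three measured compounds shows an effect at smaller amounts. The change under study is chloro in place of fluoro on an aromatic carbon, giving compound 4 `Cc1cc(NC(=O)Nc2ccc(Cl)cc2)c2ccccc2n1`. Among the measured compounds shown here, the only step among measured compounds that touches this part of the structure, a step that the two limits leave unreadable from compound 1 to compound 2, cannot be read in size, because the limit of > 25000 nM in this assay, at which 2 of the 3 values shown sit, hides any difference between the two. For the measured compounds named here, no measured step therefore points to a change beyond the usual scatter, and compound 4 is expected to sit near the same limit. The step from compound 2 to compound 4 in this assay is estimated as a step that the limit leaves unreadable from compound 2 to compound 4. Compound 4 is expected to give about 30000 nM, within a range from 12000 nM to 80000 nM.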

Compound 4, half-maximal effective concentration: > 25000 nM
Compound 4 gave a limit, no number (the forecaster's own chance of this, stated with the estimate: 75%); the middle value lies beyond the limit too.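

No size can be read for the change from fluoro to chloro between compound 2 and compound 4, because both results are limits and not numbers: the limit of > 25000 nM in this assay, at which 3 of the 4 values shown sit.
The compounds shown leave open whether 4-fluorophenyl and 4-chlorophenyl differ at all in this assay.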